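The source may report more compounds than this note shows. Statements on the series, on what has been measured and on what is new or still open speak of the compounds shown alone.

Of the compounds shown here, two have so far been measured in a functional assay on NCI-H23 cells (Homo sapiens) for cytotoxicity, read by sulforhodamine B assay, with a stated time of 48 h, tested at 1 uM; a lower number here means a stronger effect, a higher number a weaker effect of the compound at the concentration tested. Compound 1 `COc1cc(-c2cc(/C=C/C(=O)c3ccc(Cl)c(Cl)c3)[nH]n2)cc(OC)c1OC` gives 95%, and compound 2 `COc1ccc(-c2cc(/C=C/C(=O)c3ccc(N)cc3)[nH]n2)cc1` gives 93%; these two numbers lie within the usual scatter of each other, so neither can be set apart from the other, and both leave most of the cells alive at the concentration tested. Compound 3 `COc1ccc(C(=O)/C=C/c2cc(-c3cc(OC)c(OC)c(OC)c3)n[nH]2)cc1OC` has not yet been measured. It differs from compound 1 in one place: 3,4-dimethoxyphenyl in place of 3,4-dichlorophenyl on a carbonyl carbon. Among the measured compounds shown here, no measured pair in this set shows what such a change does, so the expectation rests on where compound 1 stands alone. In this assay the expected step is small, with no clear direction, and stays within the scatter: a number 1 percentage points lower from compound 1 to compound 3 (within the scatter). For compound 3 in this assay the estimate is 94%, with a range from 80% to 105%.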

Compound 3, a percentage reported as activity, at one concentration (the size of the read-out at that concentration, not a potency): 93%
Compound 3: middle estimate off by 1 percentage points, on the high side; the measured number falls inside the stated range.
By their numbers in this assay, from the lowest: compounds 2, 3 and 1 (each within the scatter of the next).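

Among the compounds shown here, this pair is the first in the set to show what a change at this place can do: on a carbonyl carbon, 3,4-dimethoxyphenyl takes the place of 3,4-dichlorophenyl, and this assay gives a number 2 percentage points lower from compound 1 to compound 3 (within the scatter). The entering group carries hydrogen-bond acceptors that the leaving group lacks, yet at this single concentration the read-out does not set the two compounds apart. No measurement shown here offers an explanation for this outcome.

On these data alone, compound 1 and compound 3 both leave most of the cells alive, so it remains open whether any group at this place can produce a clear effect on the cells. A carboxylic acid or a longer chain on this carbonyl carbon, in place of the aromatic ring, would test that further.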